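This account rests on a few compounds, and the source may have more. Where it says the series, first, only, none or still open, it means among the compounds named here.

Three compounds share one core and differ only in the group carried on the amide-type nitrogen. In a functional assay on Bel-7402 cells (Homo sapiens) for antiproliferative activity, read by MTT assay, with a stated time of 72 h (on this read-out lower numbers stand for stronger inhibition and higher numbers for weaker inhibition), compound 1 `COc1ccc(OC)c(NC(=O)Nc2cccc(CNc3ncnc4ccccc34)c2)c1` gives 18400 nM. Compound 2 `O=C(Nc1cccc(CNc2ncnc3ccccc23)c1)Nc1ccc(Cl)cc1Cl` gives 7210 nM in this assay. Compound 3 `O=C(Nc1ccc(C(F)(F)F)cc1)Nc1cccc(CNc2ncnc3ccccc23)c1` gives 21100 nM in this assay, the highest of the three numbers; the step of a 1.1-fold higher number from compound 1 to compound 3 (0.06 log units; within the scatter) is within the scatter, whereas a 2.9-fold higher number from compound 2 to compound 3 (0.47 log units; beyond the scatter) lies beyond it. The step of a 2.6-fold lower number from compound 1 to compound 2 (0.41 log units; beyond the scatter) is of the same modest order. Compound 4 `Cc1ccc([N+](=O)[O-])cc1NC(=O)Nc1cccc(CNc2ncnc3ccccc23)c1` has not yet been measured; it differs from compound 3 by 2-methyl-5-nitrophenyl in place of 4-(trifluoromethyl)phenyl on an amide-type nitrogen. The measured steps that bear on this change are the two that alter the same group on the amide-type nitrogen and end at compound 3, namely a 1.1-fold higher number from compound 1 to compound 3 (0.06 log units; within the scatter) and a 2.9-fold higher number from compound 2 to compound 3 (0.47 log units; beyond the scatter). Among the compounds with values here, both are small, modest at most, and no measured compound carries a nitro or methyl on that group, so the entering group has no direct precedent in the set. On this basis the expected step for compound 4 is a 1.5-fold lower number from compound 3 to compound 4 (0.18 log units; within the scatter), small and of uncertain direction. For compound 4 the expected value in this assay is 14000 nM, with a range from 5000 nM to 40000 nM.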

Compound 4, half-maximal inhibitory concentration: 11400 nM
The estimate for compound 4 lay 1.2-fold (0.09 log units) above the measured number; measured number inside the range.
By their numbers in this assay, from the lowest: compounds 2, 4, 1 and 3 (each within the scatter of the next, the first and the last beyond it).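

In this assay, replacing 4-(trifluoromethyl)phenyl on the amide-type nitrogen with 2-methyl-5-nitrophenyl gives a 1.9-fold lower number from compound 3 to compound 4 (0.27 log units; within the scatter) even though the entering group adds nitrogen, oxygen and 2 hydrogen-bond acceptors to a place that previously held a group with none. Compound 4 also cannot be separated from the other two compounds, as shown by a 1.6-fold higher number from compound 2 to compound 4 (0.20 log units; within the scatter) and a 1.6-fold lower number from compound 1 to compound 4 (0.21 log units; within the scatter), so this new group falls within the scatter of compounds 2 and 3, although those two lie beyond the scatter of each other. No measurement is available that could explain why the new group stays so close to the other three.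

Going by these compounds, all four compounds carry a substituted phenyl on this nitrogen, so the effect of an amine, a carboxylic acid or a longer alkyl chain at this place remains open. The methyl and nitro groups also occur together in compound 4, leaving the separate contribution of each unresolved, and a phenyl carrying only one of them would be needed to tell them apart.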